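A few compounds are considered here, and "the series" means these few. Any claim that something is new, unique, unknown or untested is made for them only; others in the source may bear on it.

Measured so far in a functional assay on the whole organism with Mus musculus as the target, in the maximal electroshock model, at a dose of 50 mg/kg by the oral route; on this read-out higher numbers stand for more inhibition at the one dose given (going by the name of the read-out) and lower numbers for less inhibition:
compound 1 `COc1cccc(/C=C/c2ccccc2)c1OCCCCN(C)C` gives 57.1%
compound 2 `C(=C/c1ccccc1OCCCCN1CCCC1)\c1ccccc1` gives 42.9%

Compound 2 stands lowest of the two numbers shown. Its nearest neighbour is compound 1, which lies higher by a gap beyond the usual scatter. The two compounds differ in more than one place, so that gap cannot be resolved into a single step; only the two values themselves are shown.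

Compound 3 `CCN1CCN(CCCCOc2ccccc2/C=C/c2ccccc2)CC1` is not yet measured. It differs from compound 2 in one place: 4-ethylpiperazin-1-yl in place of pyrrolidin-1-yl on a saturated chain carbon, four bonds along the chain from an oxygen on an aromatic ring. Among the compounds with values here, no measured step of this kind is available among the compounds here, so the size of the change has no precedent. In this assay a step of modest size is expected, with no firm basis for a direction beyond the scatter; the expected step is a number 2.1 percentage points higher from compound 2 to compound 3 (within the scatter). Compound 3 is therefore estimated at 45%, with a range from 20% to 70%.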

Compound 3, a percentage reported as inhibition, in the whole organism at one dose (the size of the read-out at that dose, not a potency): 33.3%
For compound 3 the middle estimate is 11.7 percentage points above the measured one; the measured number falls inside the stated range.
By their numbers in this assay, from the lowest: compounds 3 and 2 (each within the scatter of the next); then compound 1.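

In this assay, within the data shown here, the first readable step at this position, 4-ethylpiperazin-1-yl in place of pyrrolidin-1-yl on a saturated chain carbon, four bonds along the chain from an oxygen on an aromatic ring, gives a number 9.6 percentage points lower from compound 2 to compound 3 (within the scatter) and so stays inside the usual scatter. At this one oral dose, a five-membered ring with 1 hetero atom and 5 heavy atoms can therefore be exchanged for a six-membered ring with 2 hetero atoms and 8 heavy atoms without a resolved difference. No measurement bearing on the reason for this result is available.

One pair cannot show whether other cyclic amines, such as morpholin-4-yl or piperidin-1-yl, would also stay within the scatter. As far as these compounds go, the effect of a longer chain between the oxygen and the amine also remains open.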